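A few compounds are considered here, and "the series" means these few. Any claim that something is new, unique, unknown or untested is made for them only; others in the source may bear on it.

Measured in a functional assay on MCF7 cells (Homo sapiens) for inhibition, read by MTT assay, with a stated time of 48 h; a lower number here means a stronger inhibitor, a higher number a weaker inhibitor:
- Compound 1 `O=C1N/C(=N\Cc2ccc(C(F)(F)F)cc2)S/C1=C1/CCNC(=O)c2[nH]ccc21`: > 100000 nM (a limit, not a number)
- Compound 2 `O=C1N/C(=N\Cc2cccc(Cl)c2)S/C1=C1/CCNC(=O)c2[nH]ccc21`: 20700 nM
- Compound 3 `O=C1N/C(=N\Cc2ccccc2Cl)S/C1=C1/CCNC(=O)c2[nH]ccc21`: 21200 nM

Compound 1 stands at the limit of > 100000 nM in this assay, at which 1 of the 3 values shown sits, and this is a limit, not a number. Compound 4 `CC(C)(C)c1ccc(C/N=C2\NC(=O)/C(=C3\CCNC(=O)c4[nH]ccc43)S2)cc1` keeps the core of compound 1 but carries tert-butyl in place of trifluoromethyl on an aromatic carbon, para to a large group (tert-butyl in place of trifluoromethyl on an aromatic carbon). Within the data shown here, the only measured step, a 1.0-fold higher number from compound 2 to compound 3 (0.01 log units; within the scatter), swaps 3-chlorophenyl for 2-chlorophenyl, so it tests a different change and gives only weak guidance here. Among the measured compounds shown here, no measured step tests this swap directly, so the size of any shift in this assay remains uncertain. Compound 2 at 20700 nM and compound 3 at 21200 nM show that close relatives can give a real number, so a modest move towards a lower number is expected. The expected change is an at least 1.6-fold lower number from compound 1 to compound 4 (0.22 log units; that floor lies within the scatter) as an estimate. Compound 4 is estimated at 60000 nM (expected range 20000 nM to 150000 nM).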

Compound 4, half-maximal inhibitory concentration: 18900 nM
Compound 4: the middle estimate sits 3.2-fold (0.50 log units) above what was measured; measured number below the stated range.
By their numbers in this assay, from the lowest: compounds 4, 2 and 3 (each within the scatter of the next). At a limit, above all of these: compound 1.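

In this assay, putting tert-butyl in place of trifluoromethyl on this aromatic carbon, para to a large group, gives an at least 5.2-fold lower number from compound 1 to compound 4 (0.72 log units; beyond the scatter). Among these compounds, this is the first direct evidence that the group at this position matters: of these two groups, trifluoromethyl gives only a limit, while tert-butyl gives a real number. Compound 1 has a limit and not a number, so the step is only a floor and its true size stays unknown: the limit of > 100000 nM in this assay, at which 1 of the 4 values shown sits.

Going by these compounds, two groups at one position cannot establish a trend, so it remains open whether a methyl group, an amine or a carboxylic acid in the same place would give a lower or a higher number. On these data alone, it also remains open whether tert-butyl would give a similar step elsewhere on the same aromatic ring.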